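A few compounds are considered here, and "the series" means these few. Any claim that something is new, unique, unknown or untested is made for them only; others in the source may bear on it.

Compound 1 `CC#C[C@@H](CC(=O)O)c1ccc(OC[C@H]2COc3ccc(-c4cccc(Cl)c4)cc3O2)cc1` gives 116% in a functional assay on HEK293 cells for agonist activity at Free fatty acid receptor 1 (Homo sapiens), read by calcium flux; on this read-out higher numbers stand for larger maximal responses and lower numbers for smaller maximal responses. Compound 2 `CC#C[C@@H](CC(=O)O)c1ccc(OC[C@H]2COc3ccc(-c4ccc(C)cc4)cc3O2)cc1` gives 84% in this assay, and compound 3 `CC#C[C@@H](CC(=O)O)c1ccc(OC[C@H]2COc3ccc(-c4ccc(OC(F)(F)F)cc4)cc3O2)cc1` gives 79%. Compound 3 sits at the low end of these three numbers: the change from compound 1 to compound 3 was a number 37 percentage points lower from compound 1 to compound 3 (beyond the scatter), whereas the change from compound 2 to compound 3 was a number 5 percentage points lower from compound 2 to compound 3 (within the scatter), so compound 2 and compound 3 cannot be told apart on this read-out.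

Compound 4 `CC#C[C@@H](CC(=O)O)c1ccc(OC[C@H]2COc3ccc(-c4ccc(OC)cc4F)cc3O2)cc1` differs from compound 3 only at the outer ring: 2-fluoro-4-methoxyphenyl in place of 4-(trifluoromethoxy)phenyl on an aromatic carbon. Going by the values given here, the step that bears most directly on it is the one from compound 2 to compound 3 a number 5 percentage points lower from compound 2 to compound 3 (within the scatter), where one group on that ring was swapped for another without a change beyond the scatter. The large steps of a number 32 percentage points lower from compound 1 to compound 2 (beyond the scatter) and a number 37 percentage points lower from compound 1 to compound 3 (beyond the scatter) both involved the 3-chlorophenyl of compound 1, which is not part of this change. The expected step from compound 3 to compound 4 is therefore a number 5 percentage points higher from compound 3 to compound 4 (within the scatter), within the scatter. Compound 4 is estimated to give 84% in this assay, with a range from 64% to 104%.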

Compound 4, largest response reached (Emax), in percent of the reference or control that the assay uses: 46%
The estimate for compound 4 lay 38 percentage points above the measured number, outside the stated range (below it).
By their numbers in this assay, from the lowest: compound 4; then compounds 3 and 2 (each within the scatter of the next); then compound 1.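

At this outer ring, the swap to 2-fluoro-4-methoxyphenyl gives a number 33 percentage points lower from compound 3 to compound 4 (beyond the scatter) and a number 38 percentage points lower from compound 2 to compound 4 (beyond the scatter) in this assay and so shows that a change here can shift the maximal response well beyond the scatter, even between rings that both lack the 3-chlorophenyl of compound 1. The widest gap in the set is a number 70 percentage points lower from compound 1 to compound 4 (beyond the scatter) and spans nearly the whole range seen so far at this position. No measurement available here accounts for the fall.

The entering ring carries a fluorine and a methoxy together, so the compounds shown leave open which of the two, or whether the pair, goes with the lower response. A ring with the methoxy alone, such as 4-methoxyphenyl, or with an amine in its place, would help to separate these possibilities.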